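The source may report more compounds than this note shows. Statements on the series, on what has been measured and on what is new or still open speak of the compounds shown alone.

Measured compounds:
compound 1 `C=CCn1c(=O)/c(=C\c2cc(Br)ccc2F)[nH]c(=O)/c1=C\c1ccccc1OC` with 17400 nM
compound 2 `C=CCn1c(=O)/c(=C\c2ccc(F)c(Br)c2)[nH]c(=O)/c1=C\c1ccccc1OC` with "not active" (no number reported)
compound 3 `C=CCn1c(=O)/c(=C\c2ccc(C)cc2)[nH]c(=O)/c1=C\c1ccccc1OC` with "not active" (no number reported)

In a functional assay on HL-60 cells (Homo sapiens) for cytotoxicity, read by CCK-8 assay, with a stated time of 72 h (a lower number here means a stronger inhibitor, a higher number a weaker inhibitor), compound 1 gives 17400 nM, a weak result but still a number. Compound 2 is reported in this assay as "not active" (no number reported), with no number attached. Compound 3 likewise stands in this assay at "not active" (no number reported): no single number is available for it, and compound 2 is the one further entry in the same condition. Compound 3 therefore cannot be placed on a scale against compound 1; all that can be said is that compound 1 was quantified and compound 3 was not.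

Compound 4 `C=CCn1c(=O)/c(=C\c2cc(F)ccc2C)[nH]c(=O)/c1=C\c1ccccc1OC` differs from compound 3 in one place: 5-fluoro-2-methylphenyl in place of 4-methylphenyl on a double-bonded chain carbon bound to an aromatic carbon. For the measured compounds named here, no measured pair gives a step for this kind of change, so the direction can only be guessed from the set at hand. Going by the values given here, the one compound carrying a number, compound 1, is also one whose replaced ring bears two substituents, and compound 4 shares that feature; on that slim basis a weak but measurable value in this assay seems more likely for compound 4 than for compound 3, though a second report of no activity remains a real possibility. Compound 4 is expected in this assay at about 25000 nM, with a plausible range of 8000 nM to 80000 nM.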

Compound 4, half-maximal inhibitory concentration: 2600 nM
For compound 4 the middle estimate is 9.6-fold (0.98 log units) above the measured one; measured number below the stated range.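

In this assay compound 3, with 4-methylphenyl on the double-bonded chain carbon, stands at "not active" (no number reported) while compound 4, with 5-fluoro-2-methylphenyl there, gives 2600 nM as a measured value, so this place can hold a group that yields a number well inside the range of the series. The exchange of 5-bromo-2-fluorophenyl for 5-fluoro-2-methylphenyl brings a 6.7-fold lower number from compound 1 to compound 4 (0.83 log units; beyond the scatter) and shows that, among rings with two substituents, the identity of those substituents changes the result beyond the usual scatter. Two substituents alone do not secure a number, since compound 2 also carries two and stands at "not active" (no number reported) in this series. No measurement on hand accounts for these differences.

The compounds shown leave open whether the methyl or the fluorine of 5-fluoro-2-methylphenyl matters more, since no ring here carries either one alone in the same place. Going by these compounds, how a ring bearing an amine, a carboxylic acid or a longer alkyl chain would stand at this double-bonded chain carbon also remains open.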